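Series notes: benzyl variation on the triazole linker

A few compounds are considered here, and "the series" means these few. Any claim that something is new, unique, unknown or untested is made for them only; others in the source may bear on it.

Going by the values given here, compound 3 `O=c1ccoc2cc(OCc3cn(Cc4ccccc4Br)nn3)ccc12` holds the only number in the set: in a functional assay on HeLa cells (Homo sapiens) for cytotoxicity, read by MTT assay, with a stated time of 48 h (on this read-out lower numbers stand for stronger inhibition and higher numbers for weaker inhibition), compound 3 gives 14500 nM. Compound 1 `O=c1ccoc2cc(OCc3cn(Cc4cccc(Cl)c4)nn3)ccc12` gives in this assay only a limit, > 100000 nM. Compound 2 `O=c1ccoc2cc(OCc3cn(Cc4ccccc4F)nn3)ccc12` likewise gives only a limit, > 100000 nM, so that two of the three results sit at the limit of > 100000 nM in this assay, at which 2 of the 3 values shown sit. Compound 4 `COc1ccc(Cn2cc(COc3ccc4c(=O)ccoc4c3)nn2)cc1` is not yet measured; it differs from compound 3 by 4-methoxyphenyl in place of 2-bromophenyl on a saturated chain carbon bound to an aromatic nitrogen. The measured steps that bear on leaving the 2-bromophenyl group are an at least 6.8-fold lower number from compound 1 to compound 3 (0.83 log units; beyond the scatter) and an at least 6.8-fold lower number from compound 2 to compound 3 (0.83 log units; beyond the scatter); the step that the two limits leave unreadable from compound 1 to compound 2 adds nothing readable. Both readable steps run toward a lower number with 2-bromophenyl, so replacing it is expected to raise the number in this assay, the expected step being a 5.5-fold higher number from compound 3 to compound 4 (0.74 log units; beyond the scatter). Compound 4 is estimated at 80000 nM in this assay, with a range from 20000 nM to 300000 nM, and a limit rather than a number is quite possible.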

Compound 4, half-maximal inhibitory concentration: 14400 nM
The estimate for compound 4 lay 5.6-fold (0.74 log units) above the measured number; the measured number lies below the stated range.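

In this assay, the 2-bromobenzyl group is not alone in giving a readable number at this position: 4-methoxyphenyl in its place gives a 1.0-fold lower number from compound 3 to compound 4 (0.00 log units; within the scatter). The 4-methoxyphenyl group also stands apart from the 2-fluorophenyl and 3-chlorophenyl groups, with an at least 6.9-fold lower number from compound 2 to compound 4 (0.84 log units; beyond the scatter) and an at least 6.9-fold lower number from compound 1 to compound 4 (0.84 log units; beyond the scatter). A readable number on this saturated chain carbon therefore does not require bromine, while two compounds remain at a limit: the limit of > 100000 nM in this assay, at which 2 of the 4 values shown sit.

The compounds shown do not separate the identity of a group on the phenyl ring from its place there. As far as these compounds go, whether an amine or a carboxylic acid on that ring, or a longer chain in place of the benzyl carbon, would keep a readable number remains open.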